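The compounds below may be only part of what the source reports. "The series", "measured", "known", "first", "only" and "open" are said of these compounds alone.

Three compounds share one core and differ only in the group on an amine nitrogen in a ring. Compound 1 `Cc1ccc(S(=O)(=O)N2N=C(c3cc4ccccc4oc3=O)CC2c2ccccc2)cc1` carries a (4-methylphenyl)sulfonyl group there, and in a functional assay on PC-3 cells (Homo sapiens) for cytotoxicity, read by MTT assay, with a stated time of 48 h (on this read-out higher numbers stand for weaker inhibition and lower numbers for stronger inhibition), compound 1 gives 48600 nM. Compound 2 `O=C(CNC1CC1)N1N=C(c2cc3ccccc3oc2=O)CC1c1ccccc1` gives 28500 nM, and compound 3 `CC1CCCN(CC(=O)N2N=C(c3cc4ccccc4oc3=O)CC2c2ccccc2)C1` gives 28300 nM. These three numbers sit together: the steps of a 1.7-fold lower number from compound 1 to compound 2 (0.23 log units; within the scatter), a 1.7-fold lower number from compound 1 to compound 3 (0.23 log units; within the scatter) and a 1.0-fold lower number from compound 2 to compound 3 (0.00 log units; within the scatter) are each within the scatter, so compound 3 is not set apart from either other compound. Compound 4 `O=C(CN1CCC(O)CC1)N1N=C(c2cc3ccccc3oc2=O)CC1c1ccccc1` is the next step from compound 3: 4-hydroxypiperidin-1-yl in place of 3-methylpiperidin-1-yl on a saturated chain carbon bound to a carbonyl carbon. Within the data shown here, the only earlier step at this place, a 1.0-fold lower number from compound 2 to compound 3 (0.00 log units; within the scatter), moved nothing beyond the scatter, and the other two steps were just as small. The expected step is therefore a 1.0-fold lower number from compound 3 to compound 4 (0.00 log units; within the scatter), nothing beyond the scatter. Compound 4 is estimated at 28000 nM, within a range from 12000 nM to 65000 nM.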

Compound 4, half-maximal inhibitory concentration: "not active" (no number reported)
Compound 4: no number reported; there is nothing to compare the estimate with.
By their numbers in this assay, from the lowest: compounds 3, 2 and 1 (each within the scatter of the next).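

Among these compounds, compound 4 is reported as not active, with no number, so no step from compound 3 to compound 4 can be read. No measurement shown here bears on this result. The compounds shown leave open how far 4-hydroxypiperidin-1-yl and 3-methylpiperidin-1-yl differ in their effect on these cells.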